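Halogen steps and a hydroxymethyl change from compound 3

The source may hold more compounds than are shown below. What is called first, only, known or untested is meant among the compounds shown, and "the series" means these compounds.

Measured in an ADME assay on THP-1 cells (Homo sapiens) for cytotoxicity, read by flow cytometry and propidium iodide staining, with a stated time of 72 h; on this read-out lower numbers stand for stronger inhibition and higher numbers for weaker inhibition:
Compound 1 `Cc1nc(CS(=O)(=O)c2ccc(Cl)cc2)c([N+](=O)[O-])n1C`: 68000 nM
Compound 2 `Cc1nc(CS(=O)(=O)c2ccc(Br)cc2)c([N+](=O)[O-])n1C`: 326000 nM
Compound 3 `Cc1nc(CS(=O)(=O)c2ccc(F)cc2)c([N+](=O)[O-])n1C`: > 797000 nM (a limit, not a number)

Compound 3 is the weakest of the three, and its reading is only a limit: the limit of > 797000 nM in this assay, at which 1 of the 3 values shown sits. The change leading to compound 4 `Cc1nc(CS(=O)(=O)c2ccc(F)cc2)c([N+](=O)[O-])n1CCO` is hydroxymethyl in place of hydrogen on a saturated chain carbon bound to an aromatic nitrogen, or methyl to 2-hydroxyethyl. Among the measured compounds shown here, no measured step touches that place. For the measured compounds named here, the only steps available are halogen exchanges on an aromatic carbon: a 4.8-fold higher number from compound 1 to compound 2 (0.68 log units; beyond the scatter), an at least 2.4-fold higher number from compound 2 to compound 3 (0.38 log units; beyond the scatter) and an at least 11-fold higher number from compound 1 to compound 3 (1.06 log units; beyond the scatter). These show that a single change can move the read-out in this assay, but they give no direction for this one. No step beyond the scatter is therefore expected, and a reading reported only as a limit is likely. The expected step is an at least 1.1-fold lower number from compound 3 to compound 4 (0.05 log units; that floor lies within the scatter). For compound 4 the estimated value is 700000 nM, with an expected range of 200000 nM to 1500000 nM.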

Compound 4, half-maximal inhibitory concentration: > 728000 nM
Compound 4: only a limit was reported; the forecaster's own chance of this, stated with the estimate: 65%; middle value at least 1.0-fold (0.01 log units) away from the limit.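

Compound 3 and compound 4 are both reported in this assay only as limits, not numbers, and the step between them cannot be read. The compounds shown leave open whether methyl to 2-hydroxyethyl moves the read-out at all, and in which direction.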